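From 4-methylphenyl to 3,5-difluorophenyl on the shared core

The compounds below may be only part of what the source reports. "The series", "measured", "known", "first", "only" and "open" are said of these compounds alone.

- Compound 1 `Cc1nnsc1CO/N=C/c1c(C)nn(C)c1Oc1ccc(F)cc1`: > 50000 nM (a limit)
- Compound 2 `Cc1ccc(Oc2c(/C=N/OCc3snnc3C)c(C)nn2C)cc1`: > 50000 nM (a limit)

Both compounds were tested in a functional assay on PANC-1 cells (Homo sapiens) for inhibition, read by MTT assay, with a stated time of 48 h; on this read-out lower numbers stand for stronger inhibition and higher numbers for weaker inhibition. In this assay compound 2 gives > 50000 nM, which is a limit of the assay and not a number. Its neighbour gives no firmer reference, and the series offers only (the limit of > 50000 nM in this assay, at which 2 of the 2 values shown sit).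

Compound 3 `Cc1nnsc1CO/N=C/c1c(C)nn(C)c1Oc1cc(F)cc(F)c1` has not yet been measured. It differs from compound 2 as follows: 3,5-difluorophenyl in place of 4-methylphenyl on an oxygen on an aromatic ring. Among the compounds with values here, the one measured step is a step that the two limits leave unreadable from compound 1 to compound 2, and no size can be read from it. Within the data shown here, no step of definite size or direction is therefore expected in this assay, and compound 3 is expected to remain weak there, possibly reported only as a limit. The estimate for compound 3 is an expected 50000 nM, with an expected range of 25000 nM to 100000 nM. This estimate means an expected step: a number no higher from compound 2 to compound 3 (the limit leaves the size open).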

Compound 3, half-maximal inhibitory concentration: > 50000 nM
Compound 3 was reported as a limit; the forecaster's own chance of this, stated with the estimate: 80%; the middle value sits exactly at the limit.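

No step can be read among compound 1, compound 2 and compound 3 in this assay, as all three stop at the same limit of the assay: the limit of > 50000 nM in this assay, at which 3 of the 3 values shown sit.

The compounds shown leave open how far these three differ from one another, and whether any group on that oxygen gives a readable value in this assay.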